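The source may report more compounds than this note shows. Statements on the series, on what has been measured and on what is new or still open speak of the compounds shown alone.

Working notes on the series. Compound 1 `CCOc1cc(/C=N/Nc2nc(N)c3ncn([C@@H]4O[C@H](CO)[C@@H](O)[C@H]4O)c3n2)ccc1O` and compound 2 `Nc1nc(N/N=C/c2ccc(Cl)c(C(F)(F)F)c2)nc2c1ncn2[C@@H]1O[C@H](CO)[C@@H](O)[C@H]1O` share one core and differ only in the aryl group on the carbon with a double bond to nitrogen. In an assay on CHO-K1 cells for displacement of a labelled ligand from adenosine receptor A1 (Homo sapiens), read by scintillation counting, with a stated time of 60 min (on this read-out lower numbers stand for stronger inhibition and higher numbers for weaker inhibition), compound 1 gives 6940 nM. In this assay compound 2 reaches only a limit of the assay, > 10000 nM, so for compound 2 there is a bound and no number. Among the compounds with values here, the step of an at least 1.4-fold higher number from compound 1 to compound 2 (0.15 log units; that floor lies within the scatter) is the only measured step in the set, and its size is capped by the limit of > 10000 nM in this assay, at which 1 of the 2 values shown sits. Compound 3 `CN(C)c1ccc(/C=N/Nc2nc(N)c3ncn([C@@H]4O[C@H](CO)[C@@H](O)[C@H]4O)c3n2)cc1` is the next member and has not yet been measured in this assay. It differs from compound 2 by 4-(dimethylamino)phenyl in place of 4-chloro-3-(trifluoromethyl)phenyl on a carbon with a double bond to nitrogen. The one measured step also swaps an aryl group at that same carbon and moves the number no further than its floor, so an aryl swap at this place has so far shown no change resolved beyond the scatter. The expected step from compound 2 to compound 3 is an at least 1.1-fold lower number from compound 2 to compound 3 (0.04 log units; that floor lies within the scatter), with compound 3 expected to sit close to the limit. For compound 3 the estimate in this assay is 9000 nM, in the range 3000 nM to 30000 nM.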

Compound 3, inhibition constant: > 10000 nM
Compound 3 gave a limit, no number; the forecaster's own chance of this, stated with the estimate: 50%; middle value at least 1.1-fold (0.04 log units) from the limit.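

A second aryl swap on the carbon with a double bond to nitrogen, this time to 4-(dimethylamino)phenyl, which carries a hydrogen-bond acceptor where 4-chloro-3-(trifluoromethyl)phenyl carries none, again gives no number: in this assay compound 3 gives > 10000 nM, a limit of the assay and not a number. Measured against the 3-ethoxy-4-hydroxyphenyl group, the change reads as an at least 1.4-fold higher number from compound 1 to compound 3 (0.15 log units; that floor lies within the scatter), so this floor, like the earlier one, resolves no change. The step between compound 2 and compound 3 cannot be read, and two aryl groups with different substituents now share the same bound: the limit of > 10000 nM in this assay, at which 2 of the 3 values shown sit.

Within the data shown here, it remains open how far compound 2 and compound 3 lie past the limit, and whether any aryl group at this carbon gives a number resolved from that of compound 1, the only member with a number so far. A plain 4-hydroxyphenyl or 3-ethoxyphenyl group would separate the two substituents of compound 1, and an aryl group bearing a carboxylic acid or a primary amine would extend the range of groups tested at this place.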